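The source may report more compounds than this note shows. Statements on the series, on what has been measured and on what is new or still open speak of the compounds shown alone.

The account concerns three measured compounds and one that awaits measurement, all read in a functional assay on HOS-TE85 cells (Homo sapiens) for inhibition, read by CCK-8 assay, with a stated time of 72 h; on this read-out lower numbers stand for stronger inhibition and higher numbers for weaker inhibition. Compound 1 `O=C(NCCCCc1ccccc1)c1cccc(C2SCC(=O)N2c2ccc(-c3ccccc3)cc2)c1` is reported only as a limit: in this assay compound 1 gives > 1000 nM. Compound 2 `CCOC(=O)c1sc(N2C(=O)CSC2c2cccc(C(=O)NCCCCn3cccn3)c2)nc1C` gives 430 nM in this assay, and compound 3 `COc1ccccc1N1C(=O)CSC1c1cc(C)cc(C(=O)NCCCCc2ccccc2)c1` gives 16.2 nM in this assay. Among the numbers shown, compound 1 therefore stands at the weak end, on the limit line (the limit of > 1000 nM in this assay, at which 1 of the 3 values shown sits), while compound 3 sits lowest of the three.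

Compound 4 `O=C(NCCCCc1ccccc1)c1cccc(C2SCC(=O)N2c2ccccc2F)c1` differs from compound 1 in one place on the shared core: 2-fluorophenyl in place of 4-phenylphenyl on an amide-type nitrogen in a ring. Going by the values given here, no measured pair with this same change is available, so the size of the step cannot be read from a neighbour. Because compound 1 is known only as a limit, the step to compound 4 can be bounded on one side only. Compound 3 gives 16.2 nM in this assay, and on that showing a smaller group on the amide-type nitrogen in a ring is compatible with strong inhibition, so the step is expected to run toward stronger inhibition, with a size of an at least 8.3-fold lower number from compound 1 to compound 4 (0.92 log units; beyond the scatter) estimated. Compound 4 is thus expected to give 120 nM in this assay, within a range from 20 nM to 900 nM.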

Compound 4, half-maximal inhibitory concentration: 34.1 nM
Beside the measured number, compound 4's estimate is 3.5-fold (0.55 log units) above it; the measured number falls inside the stated range.
By their numbers in this assay, from the lowest: compound 3; then compound 4; then compound 2. At a limit, above all of these: compound 1.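

In this assay, the amide-type nitrogen in a ring proves to be a place where the choice of group matters greatly: 2-fluorophenyl in place of 4-phenylphenyl gives an at least 29-fold lower number from compound 1 to compound 4 (1.46 log units; beyond the scatter). The change takes away one of the two six-membered aromatic rings of carbon only and brings in a fluorine, and this single step cannot show how much of the gain belongs to each. The true size of the step remains a bound, and the value of compound 1 in this pair is a limit and not a number: the limit of > 1000 nM in this assay, at which 1 of the 4 values shown sits.

The compounds shown leave open what the fluorine itself contributes, as a plain phenyl on this nitrogen does not appear among them, nor does a chlorine or a methyl group in the place of the fluorine. They also leave open whether an aromatic ring is needed on this nitrogen at all, a question that a cyclohexyl group or a short alkyl chain there could address.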